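Sulfonyl substituent swap in the acylsulfonamide series

This account rests on a few compounds, and the source may have more. Where it says the series, first, only, none or still open, it means among the compounds named here.

Compound 2 `N#Cc1cc2c(nc1N1CCC(C(=O)NS(=O)(=O)c3ccc(Cl)s3)CC1)COC2=O` is the reference point. In a functional assay (Platelet, plasma) for inhibition, with Homo sapiens as the target (a lower number here means a stronger inhibitor, a higher number a weaker inhibitor), compound 2 gives 4470 nM, the higher of the two finite numbers in hand; the nearest is compound 3 `CC1(C(=O)NS(=O)(=O)c2ccc(Cl)s2)CCN(c2nc3c(cc2C#N)C(=O)OC3)CC1`, which gives 1640 nM. Compound 1 `CC1OC(=O)c2cc(C#N)c(N3CCC(C(=O)NS(=O)(=O)c4ccc(Cl)s4)CC3)nc21` returns only a limit of the assay, > 300000 nM, as noted in the limit of > 300000 nM in this assay, at which 1 of the 3 values shown sits.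

Both measured steps concern the saturated ring carbon: an at least 67-fold lower number from compound 1 to compound 2 (1.82 log units; beyond the scatter), and a 2.7-fold lower number from compound 2 to compound 3 (0.44 log units; beyond the scatter). Neither touches the sulfonyl substituent.

Compound 4 `N#Cc1cc2c(nc1N1CCC(C(=O)NS(=O)(=O)Cc3ccc(F)cc3F)CC1)COC2=O` differs from compound 2 as follows: 2,4-difluorobenzyl in place of 5-chlorothiophen-2-yl on a sulfonyl sulfur. Going by the values given here, no measured step in this set changes that part of the molecule, so the measured steps give no direct guide to the size or direction of the change in this assay. With the shared core, the nitrile and the acylsulfonamide kept, the number for compound 4 is expected to stay in the same region as compound 2, with a wide band of uncertainty. Compound 4 is estimated at 8000 nM, between 1500 nM and 40000 nM. The expected step is a 1.8-fold higher number from compound 2 to compound 4 (0.25 log units; within the scatter).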

Compound 4, half-maximal inhibitory concentration: 5200 nM
The estimate for compound 4 lay 1.5-fold (0.19 log units) above the measured number, within the range that was stated.
By their numbers in this assay, from the lowest: compound 3; then compounds 2 and 4 (each within the scatter of the next). At a limit, above all of these: compound 1.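

In this assay, going by these compounds alone, the sulfonyl substituent now has a measured step, where the earlier steps concerned only the saturated ring carbon: 2,4-difluorobenzyl in place of 5-chlorothiophen-2-yl gives a 1.2-fold higher number from compound 2 to compound 4 (0.07 log units; within the scatter) and the pair reads alike. For this pair, a six-membered aromatic ring of carbon only, held through benzyl, serves on the sulfonyl sulfur as well as a five-membered aromatic ring with a hetero atom, so the sulfur and chlorine of 5-chlorothiophen-2-yl are not needed for this level of inhibition. No measured property bears on why the two substituents read alike.

Still open, from the compounds shown here alone, is whether a small methyl on the sulfonyl sulfur, or a chain ending in a carboxylic acid or an amine, reads the same. Also open, going by these compounds, is whether 2,4-difluorobenzyl combines with the methyl on the saturated ring carbon of compound 3.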